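The compounds below may be only part of what the source reports. "The series", "measured", "known", "first", "only" and "open" are said of these compounds alone.

In a functional assay (aorta) with Rattus norvegicus as the target (a lower number here means that less compound is needed, a higher number that more compound is needed for the effect), compound 1 `COc1ccc(-c2nc(CN)sc2-c2ccc(OC)cc2)cc1` gives 7.7 uM. Compound 2 `CCOC(=O)/C(C#N)=C/c1nc(-c2ccc(OC)cc2)c(-c2ccc(OC)cc2)s1` reaches only a limit, > 100 uM. Compound 3 `COc1ccc(-c2nc(/C=C/C(=O)O)sc2-c2ccc(OC)cc2)cc1` gives 55 uM, the higher of the two actual numbers here. Compound 4 `COc1ccc(-c2nc(CCC(=O)O)sc2-c2ccc(OC)cc2)cc1` differs from compound 3 in a single group, 2-carboxyethyl in place of 2-carboxyethenyl on an aromatic carbon. Two measured steps replaced a whole group at this place, a 7.1-fold higher number from compound 1 to compound 3 (0.85 log units; beyond the scatter) and an at least 12-fold higher number from compound 1 to compound 2 (1.11 log units; beyond the scatter). The step of an at least 1.8-fold lower number from compound 2 to compound 3 (0.25 log units; that floor lies within the scatter) gives only a floor, within the scatter. None of these keeps the carboxy end while altering the chain, so they offer no direct size for this change. The expected step in this assay is small and within the scatter, estimated as a 1.2-fold lower number from compound 3 to compound 4 (0.09 log units; within the scatter). For compound 4 the estimated value is 45 uM, with a range from 15 uM to 100 uM.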

Compound 4, concentration for half-maximal effect: > 100 uM
Compound 4: a limit, no number; the forecaster's own chance of this, stated with the estimate: 20%; middle value at least 2.2-fold (0.34 log units) from the limit.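

In this assay compound 4 reaches > 100 uM and that is a limit, not a number. The step of an at least 1.8-fold higher number from compound 3 to compound 4 (0.25 log units; that floor lies within the scatter) is only a floor within the scatter, so 2-carboxyethyl and 2-carboxyethenyl cannot be told apart here, because the read-out stops at a limit: the limit of > 100 uM in this assay, at which 2 of the 4 values shown sit. The step of an at least 12-fold higher number from compound 1 to compound 4 (1.11 log units; beyond the scatter) shows that the saturated acid chain also needs far more compound than aminomethyl, while the step from compound 2 to compound 4 cannot be read.

Still open, from the compounds shown here alone, is how an amine on a longer chain would compare with aminomethyl, and whether a carboxylic acid on a longer chain would give a readable number.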